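This account rests on a few compounds, and the source may have more. Where it says the series, first, only, none or still open, it means among the compounds named here.

The measured compounds:
Compound 1 is `CCCn1c(NC(=O)c2cc(C)nn2CC)nc2cc(C(N)=O)ccc21`. In an assay for activation of interferon regulatory factor 3 (Homo sapiens), read by a luciferase reporter, with a stated time of 20 h (a higher number here means that more compound is needed for the effect, a lower number that less compound is needed), compound 1 gives > 100000 nM, which is a limit of the assay and not a number.
Compound 2 is `CCn1nc(C)cc1C(=O)Nc1nc2cc(C(N)=O)cc(OC)c2n1CCCNC(=O)OCc1ccccc1`. In this assay compound 2 gives > 100000 nM, again a limit.
Compound 3 is `COc1cc(C(N)=O)cc2nc(NC(=O)c3ccc4ccccc4n3)n(CCCNC(=O)OCc3ccccc3)c12`. In this assay compound 3 gives > 100000 nM, also a limit.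

Compound 2 thus stands only at a limit, and every value shown here sits at the same point: the limit of > 100000 nM in this assay, at which 3 of the 3 values shown sit. The step that the two limits leave unreadable from compound 2 to compound 3 changes the group on the carbonyl carbon; with a limit at each end its size cannot be read.

Compound 4 is `CCn1nc(C)cc1C(=O)Nc1nc2cc(C(N)=O)ccc2n1CCCNC(=O)OCc1ccccc1`. It differs from compound 2 in one place: hydrogen in place of methoxy on an aromatic carbon. Among the measured compounds shown here, no measured pair shows this exact change, and the only single-place step among the measured compounds, from compound 2 to compound 3, is itself unreadable. Compound 1 carries the same ring with the carbamoyl group and without the methoxy, and compound 1 too sits at the limit. Nothing here suggests that removing the methoxy brings the number into the readable range. Compound 4 is therefore expected to remain at the limit as well, with an estimated step that the limit leaves unreadable from compound 2 to compound 4. The estimate for compound 4 is 150000 nM, ranging from 30000 nM to 1000000 nM.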

Compound 4, half-maximal effective concentration: > 100000 nM
Compound 4 was reported as a limit; the forecaster's own chance of this, stated with the estimate: 85%; the middle value does not contradict the limit.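

Compound 4 ends at a limit of the assay, not a number, so the steps to it from compound 1 and from compound 2 cannot be read, and all the values stand at one point: the limit of > 100000 nM in this assay, at which 4 of the 4 values shown sit.

The compounds shown leave open whether methoxy or (benzyloxycarbonyl)amino has any effect on the value in this assay.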